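Exchanging an acetylphenyl group for an indole

This account rests on a few compounds, and the source may have more. Where it says the series, first, only, none or still open, it means among the compounds named here.

In a functional assay on MCF7 cells (Homo sapiens) for inhibition, read by CCK-8 assay, with a stated time of 48 h (on this read-out lower numbers stand for stronger inhibition and higher numbers for weaker inhibition), compound 1 `COc1cc(-c2ccnc3cc(-c4cccc(C#N)c4)nn23)cc(OC)c1OC` gives > 10000 nM, which is a limit of the assay and not a number. Compound 2 `COc1cc(-c2ccnc3cc(-c4cn(C)c5ccccc45)nn23)cc(OC)c1OC` gives 95 nM. Compound 3 `COc1cc(-c2ccnc3cc(-c4ccc(C(C)=O)cc4)nn23)cc(OC)c1OC` gives 5230 nM, the higher of the two actual numbers. Compound 4 `COc1cc(-c2ccnc3cc(-c4ccc5ccn(C)c5c4)nn23)cc(OC)c1OC` carries 1-methyl-1H-indol-6-yl in place of 4-acetylphenyl (1-methyl-1H-indol-6-yl in place of 4-acetylphenyl on an aromatic carbon).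

Going by the values given here, two measured steps bear on this change. There is a large 55-fold higher number from compound 2 to compound 3 (1.74 log units; beyond the scatter), beyond the scatter, when 4-acetylphenyl replaces 1-methyl-1H-indol-3-yl, and a large at least 100-fold lower number from compound 1 to compound 2 (2.02 log units; beyond the scatter) when that indole replaces 3-cyanophenyl. The indole of compound 4 is a 6-yl group rather than a 3-yl group, so only part of that gap is expected to return in this assay, as an estimated 13-fold lower number from compound 3 to compound 4 (1.12 log units; beyond the scatter). Compound 4 is estimated at 400 nM, within a range of 60 nM to 3000 nM.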

Compound 4, half-maximal inhibitory concentration: 74 nM
Estimate against measurement, compound 4: 5.4-fold (0.73 log units) above, within the range that was stated.
By their numbers in this assay, from the lowest: compounds 4 and 2 (each within the scatter of the next); then compound 3. At a limit, above all of these: compound 1.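

In this assay, 1-methyl-1H-indol-6-yl on this aromatic carbon proves far better than 4-acetylphenyl, with a 71-fold lower number from compound 3 to compound 4 (1.85 log units; beyond the scatter). Changing the indole's point of attachment from 1-methyl-1H-indol-3-yl to 1-methyl-1H-indol-6-yl gives a 1.3-fold lower number from compound 2 to compound 4 (0.11 log units; within the scatter), so among the compounds shown, both indoles give low numbers and both substituted phenyl groups give high numbers. The step from the 3-cyanophenyl group, an at least 130-fold lower number from compound 1 to compound 4 (2.13 log units; beyond the scatter), rests on a limit and not a number: the limit of > 10000 nM in this assay, at which 1 of the 4 values shown sits.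

Still open, as far as these compounds go, is whether the methyl on the indole matters. From the compounds shown here alone, it is also open whether a phenyl group carrying an amine could give numbers as low as the indoles do.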